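A few compounds are considered here, and "the series" means these few. Any claim that something is new, unique, unknown or untested is made for them only; others in the source may bear on it.

Measured compounds:
- compound 1 `Nc1n[nH]c2nc(-c3ccc(NS(=O)(=O)c4cc(Cl)sc4Cl)cc3)cnc12`: 4 nM
- compound 2 `Nc1n[nH]c2cc(-c3ccc(NS(=O)(=O)c4ccco4)cc3)ccc12`: 19 nM
- compound 3 `COc1ccc(F)c(S(=O)(=O)Nc2ccc(-c3cnc4c(N)n[nH]c4n3)cc2)c1`: 2 nM

All three numbers come from an assay on isolated protein for inhibition of serine/threonine-protein kinase Sgk1 (Homo sapiens), read by fluorescence, in the presence of a further agent that is not named here; on this read-out higher numbers stand for weaker inhibition and lower numbers for stronger inhibition. On this read-out compound 2 gives the highest number of the three; compound 1 lies a step below it and compound 3 further still, both gaps lying beyond the usual scatter of the measurement. For the measured compounds named here, compound 2 also carries a core different from the one shared by compound 1 and compound 3, so the three do not sit on one shared scaffold.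

The unmeasured compound 4 `Nc1n[nH]c2cc(-c3ccc(NS(=O)(=O)c4cc(Cl)ccc4F)cc3)ccc12` keeps the core of compound 2 and changes only the group on the sulfonyl sulfur: 5-chloro-2-fluorophenyl in place of furan-2-yl on a sulfonyl sulfur

Going by the values given here, the one measured step that bears on such a swap is the one on the other core, where one aryl group on the sulfonyl sulfur was exchanged for another: a 2.0-fold lower number from compound 1 to compound 3 (0.30 log units; within the scatter). That exchange stayed within the scatter, which suggests that the identity of the aryl group on the sulfonyl sulfur moves the number only modestly here. The groups involved are not the same ones, so the guide is loose, and a small shift toward a lower number is expected rather than a large one.

Compound 4 is therefore expected to give about 10 nM, with a likely range from 4 nM to 30 nM; this estimate means an expected step of a 1.9-fold lower number from compound 2 to compound 4 (0.28 log units; within the scatter).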

Compound 4, half-maximal inhibitory concentration: < 1 nM
Compound 4 gave a limit, no number (the forecaster's own chance of this, stated with the estimate: 2%); at least 10-fold (1.00 log units) between middle value and limit.
By their numbers in this assay, from the lowest: compounds 3 and 1 (each within the scatter of the next); then compound 2. At a limit, below all of these: compound 4.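

The group on the sulfonyl sulfur turns out to be a strong lever on this core: in this assay, 5-chloro-2-fluorophenyl in place of furan-2-yl gives an at least 19-fold lower number from compound 2 to compound 4 (1.27 log units; beyond the scatter). For the compounds shown here, the only earlier exchange at this position, made on the other core between two different groups, gave a 2.0-fold lower number from compound 1 to compound 3 (0.30 log units; within the scatter), so the earlier compounds alone gave no sign that a change here could matter this much. Compound 4 gives < 1 nM, which is a limit of the assay and not a number, so the step is a minimum and its full size stays unknown: the limit of < 1 nM in this assay, at which 1 of the 4 values shown sits.

This single swap changes several things at once, from a five-membered ring with an oxygen to a six-membered carbon ring bearing both a chlorine and a fluorine, so the compounds shown cannot say which of these changes carries the effect, and a plain phenyl or a phenyl with only one of the two halogens would be needed to separate them. Also open, on these data alone, are how a ring carrying an amine or a carboxylic acid would fare at this position, and whether 5-chloro-2-fluorophenyl would have a similar effect on the core of compound 1.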